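Replacing One Phenyl Group with Another on the Amide Carbonyl

The source may report more compounds than this note shows. Statements on the series, on what has been measured and on what is new or still open speak of the compounds shown alone.

Compound 1, `NC(=O)c1c(NC(=O)c2ccccc2)sc2c1CCN(C(=S)Nc1ccccc1Cl)C2`: 11800 nM
Compound 2, `NC(=O)c1c(NC(=O)c2ccccc2I)sc2c1CCN(C(=S)Nc1ccccc1Cl)C2`: 17500 nM
Compound 3, `NC(=O)c1c(NC(=O)c2ccccc2C(F)(F)F)sc2c1CCN(C(=S)Nc1ccccc1Cl)C2`: 21900 nM

All three were tested in a functional assay on MKN-74 cells (Homo sapiens) for antiproliferative activity, with a stated time of 24 h; on this read-out higher numbers stand for weaker inhibition and lower numbers for stronger inhibition. Compound 3 gives the highest of the three numbers, but its gaps to the other two fall within the scatter: a 1.9-fold higher number from compound 1 to compound 3 (0.27 log units; within the scatter), and a 1.3-fold higher number from compound 2 to compound 3 (0.10 log units; within the scatter). Compound 4, `Cc1ccc(C(=O)Nc2sc3c(c2C(N)=O)CCN(C(=S)Nc2ccccc2Cl)C3)cc1`, differs from compound 3 by one change: 4-methylphenyl in place of 2-(trifluoromethyl)phenyl on a carbonyl carbon. For the measured compounds named here, the only steps that touch this part of the molecule, a 1.9-fold higher number from compound 1 to compound 3 (0.27 log units; within the scatter) and a 1.3-fold higher number from compound 2 to compound 3 (0.10 log units; within the scatter), both stayed within the scatter, so no shift beyond the scatter is expected in this assay. Compound 4 is therefore expected to give about 14000 nM, with a likely range of 6000 nM to 35000 nM, which means an expected step of a 1.6-fold lower number from compound 3 to compound 4 (0.19 log units; within the scatter).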

Compound 4, half-maximal inhibitory concentration: 11300 nM
Beside the measured number, compound 4's estimate is 1.2-fold (0.09 log units) above it; the measured number falls inside the stated range.
By their numbers in this assay, from the lowest: compounds 4, 1, 2 and 3 (each within the scatter of the next).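

Placing 4-methylphenyl on this carbonyl carbon stays within the scatter in this assay, whichever group it replaces: (a 1.9-fold lower number from compound 3 to compound 4 (0.29 log units; within the scatter)), (a 1.5-fold lower number from compound 2 to compound 4 (0.19 log units; within the scatter)) and (a 1.0-fold lower number from compound 1 to compound 4 (0.02 log units; within the scatter)). Phenyl, 2-iodophenyl, 2-(trifluoromethyl)phenyl and 4-methylphenyl therefore cannot be told apart on this read-out. No supporting measurement bears on why these groups read alike.

As far as these compounds go, it remains open whether anything other than these phenyl groups would move the number beyond the scatter, such as a phenyl ring carrying an amine or a carboxylic acid, or a longer alkyl chain in place of the ring.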